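This account rests on a few compounds, and the source may have more. Where it says the series, first, only, none or still open, it means among the compounds named here.

Measured in a physicochemical assay for solubility, in phosphate buffer, at pH 7.4; a lower number here means a less soluble compound, a higher number a more soluble compound:
Compound 1 `OCC1CCN(c2nccnc2OC2CN(c3ncc4ccccc4n3)C2)CC1`: 174000 nM
Compound 2 `OCCC1CCN(c2nccnc2OC2CN(c3ccc4ccccc4n3)C2)CC1`: 84000 nM

Compound 2, at 84000 nM, holds the lower of the two numbers, and its gap to compound 1 lies beyond the usual scatter. Compound 3 `OC1CCN(c2nccnc2OC2CN(c3ccc4ccccc4n3)C2)CC1` carries hydroxy in place of 2-hydroxyethyl on a saturated ring carbon. Within the data shown here, no pair of measured compounds differs by this change alone, so the expectation is tentative: a modest rise in this assay. The estimated step is a 1.3-fold higher number from compound 2 to compound 3 (0.12 log units; within the scatter). For compound 3 the expected value is 110000 nM, with an estimated range of 50000 nM to 240000 nM.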

Compound 3, solubility: 99000 nM
Beside the measured number, compound 3's estimate is 1.1-fold (0.05 log units) above it, within the range that was stated.
By their numbers in this assay, from the lowest: compounds 2, 3 and 1 (each within the scatter of the next, the first and the last beyond it).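

In this assay, among these compounds, the step of a 1.2-fold higher number from compound 2 to compound 3 (0.07 log units; within the scatter) for hydroxy in place of 2-hydroxyethyl is the first reading of any change at this saturated ring carbon. It shows that the two groups cannot be told apart here, so the shorter 4-hydroxypiperidin-1-yl serves as well as 4-(2-hydroxyethyl)piperidin-1-yl in this pair. No measurement at hand accounts for this result. Still open, going by these compounds, is whether an amine or a carboxylic acid on this carbon, or a longer chain, would give a step beyond the scatter.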